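A Selenium-Bearing Replacement Tested Against Breast Cancer Cells

This account rests on a few compounds, and the source may have more. Where it says the series, first, only, none or still open, it means among the compounds named here.

Compound 1 `CS/C(=N\C(=O)c1ccno1)NC(=O)c1ccno1` and compound 2 `CS/C(=N\C(=O)c1ccco1)NC(=O)c1ccco1` both carry a methylsulfanyl group on a carbon with a double bond to nitrogen; how their two cores differ is not broken down here. In a functional assay on MCF7 cells (Homo sapiens) for cytotoxicity, read by MTT assay, with a stated time of 72 h (on this read-out higher numbers stand for weaker inhibition of growth and lower numbers for stronger inhibition of growth), compound 1 gives only a limit of the assay, > 100000 nM. In the same assay compound 2 likewise reaches only a limit, > 100000 nM. Compound 3 `O=C(/N=C(/NC(=O)c1ccno1)[Se]Cc1ccccc1)c1ccno1` arises from compound 1 by a group of 8 heavy atoms (7 carbon, 1 selenium; one six-membered aromatic ring of carbon only) in place of a group of 2 heavy atoms (1 carbon, 1 sulfur; no ring), on a carbon with a double bond to nitrogen. In this assay compound 3 again gives only a limit, > 100000 nM. The step that the two limits leave unreadable from compound 1 to compound 3 therefore cannot be read, since both of its ends sit at the limit of > 100000 nM in this assay, at which 3 of the 3 values shown sit. Compound 4 `O=C(/N=C(/NC(=O)c1ccco1)[Se]Cc1ccccc1)c1ccco1` stands to compound 2 as compound 3 stands to compound 1, through the same change, (a group of 8 heavy atoms (7 carbon, 1 selenium; one six-membered aromatic ring of carbon only) in place of a group of 2 heavy atoms (1 carbon, 1 sulfur; no ring), on a carbon with a double bond to nitrogen). With all three measured values resting at the limit, nothing in this set shows a value inside the measurable range, so the step is expected to be a step that the limit leaves unreadable from compound 2 to compound 4. For compound 4 in this assay the expected value is 150000 nM, most likely reported once more as a limit, within 60000 nM to 400000 nM.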

Compound 4, concentration for total growth inhibition: 58000 nM
Estimate against measurement, compound 4: 2.6-fold (0.41 log units) above; measured number outside the range, below it.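

In this assay, putting the selenium-bearing group of 8 heavy atoms in place of methylsulfanyl gives an at least 1.7-fold lower number from compound 2 to compound 4 (0.23 log units; that floor lies within the scatter), and compound 4, at 58000 nM, is the only compound shown with a number rather than a limit. Within the data shown here, the same change on the core of compound 1 cannot be read, as compound 1 and compound 3 both rest at a limit of the assay: the limit of > 100000 nM in this assay, at which 3 of the 4 values shown sit. The series therefore does not show that the change carries from one core to the other, nor that it fails to, as the floor of the one readable step lies within the scatter and the other step has no size.

Going by these compounds, whether a methyl group on the selenium, a longer chain or an amine at this carbon would give a number on either core stays open. The selenium and the six-membered aromatic ring enter together in compound 3 and compound 4, and which of them goes with the step is also left open.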